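Straightening the Chain on an Acrylamide Warhead

A few compounds are considered here, and "the series" means these few. Any claim that something is new, unique, unknown or untested is made for them only; others in the source may bear on it.

Measured so far in a functional assay on A-431 cells (Homo sapiens) for inhibition, read by MTT assay, with a stated time of 72 h; on this read-out higher numbers stand for weaker inhibition and lower numbers for stronger inhibition:
- compound 1 `C=CC(=O)Nc1cccc(Oc2nc(Nc3cccc(OC)c3)nc3ccsc23)c1` gives 4790 nM
- compound 2 `COc1cccc(Nc2nc(Oc3cccc(NC(=O)C=C(C)C)c3)c3sccc3n2)c1` gives 25800 nM
- compound 3 `COc1cccc(Nc2nc(Oc3cccc(NC(=O)/C=C/C(C)C)c3)c3sccc3n2)c1` gives 23400 nM

All three share one core and differ only in the group on the carbonyl carbon of the amide. Compound 3 stands second highest of the three numbers; its nearest neighbour is compound 2, at a distance within the scatter, while compound 1 lies furthest below it. The two steps away from compound 1, a 5.4-fold higher number from compound 1 to compound 2 (0.73 log units; beyond the scatter) and a 4.9-fold higher number from compound 1 to compound 3 (0.69 log units; beyond the scatter), both go beyond the scatter, whereas the step of a 1.1-fold lower number from compound 2 to compound 3 (0.04 log units; within the scatter) does not.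

Compound 4 `CCC/C=C/C(=O)Nc1cccc(Oc2nc(Nc3cccc(OC)c3)nc3ccsc23)c1` keeps every atom of compound 3 but joins them differently: propyl in place of isopropyl on a double-bonded chain carbon bound to a double-bonded chain carbon. Within the data shown here, no measured pair shows exactly this rearrangement. The closest guide is the step from compound 2 to compound 3, where a change of branching on the same chain left the number essentially where it was. On that basis the expectation for compound 4 in this assay is a step of a 1.1-fold lower number from compound 3 to compound 4 (0.03 log units; within the scatter), within the scatter, in no clear direction. The estimate for compound 4 is therefore 22000 nM, with a range from 9000 nM to 55000 nM.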

Compound 4, half-maximal inhibitory concentration: 8090 nM
Beside the measured number, compound 4's estimate is 2.7-fold (0.43 log units) above it; the whole stated range lies above it.
By their numbers in this assay, from the lowest: compounds 1 and 4 (each within the scatter of the next); then compounds 3 and 2 (each within the scatter of the next).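

In this assay, how the same carbon atoms are joined at this place does matter: moving from isopropyl to propyl gives a clear step (a 2.9-fold lower number from compound 3 to compound 4 (0.46 log units; beyond the scatter)), beyond the scatter, whereas the earlier change of branching on this chain (a 1.1-fold lower number from compound 2 to compound 3 (0.04 log units; within the scatter)) stayed within it. The straight pent-1-en-1-yl chain also stands apart from the 2-methylprop-1-en-1-yl chain (a 3.2-fold lower number from compound 2 to compound 4 (0.50 log units; beyond the scatter)), yet it cannot be told apart from plain vinyl (a 1.7-fold higher number from compound 1 to compound 4 (0.23 log units; within the scatter)), so among these four compounds extra chain carbons on the carbonyl carbon do not by themselves weaken inhibition beyond the scatter, and only the two branched chains, in compound 2 and compound 3, do so. Nothing measured here says why the straight and branched chains part ways.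

Still open, from the compounds shown here alone, is how far the straight chain can grow, since a longer chain such as hex-1-en-1-yl could stay level with vinyl or could fall away. Also open, going by these compounds, is whether a dimethylamino group at the end of the chain would keep the number in the range of compound 1 and compound 4.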